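Changing the Amide Aryl Group: From Compound 3 to Compound 4

The compounds below may be only part of what the source reports. "The series", "measured", "known", "first", "only" and "open" are said of these compounds alone.

Three compounds built on the same core were measured in a functional assay on HeLa cells (Homo sapiens) for antiproliferative activity, read by CCK-8 assay, with a stated time of 72 h; on this read-out higher numbers stand for weaker inhibition and lower numbers for stronger inhibition. Compound 1 `Cc1ccc(C(=O)Nc2cccc(-c3oc4cc(-c5ccc(F)cc5)ccc4c(=O)c3O)c2)cc1` gives 6190 nM, compound 2 `O=C(Nc1cccc(-c2oc3cc(-c4ccc(F)cc4)ccc3c(=O)c2O)c1)c1ccc(F)cc1F` gives 10700 nM, and compound 3 `O=C(Nc1cccc(-c2oc3cc(-c4ccc(F)cc4)ccc3c(=O)c2O)c1)c1ccc(C(F)(F)F)cc1` gives 17400 nM, the highest of the three numbers. The step of a 2.8-fold higher number from compound 1 to compound 3 (0.45 log units; beyond the scatter) is modest yet beyond the scatter, whereas a 1.6-fold higher number from compound 2 to compound 3 (0.21 log units; within the scatter) stays within it. Compound 4 `O=C(Nc1cccc(-c2oc3cc(-c4ccc(F)cc4)ccc3c(=O)c2O)c1)c1cccc(F)c1` differs from compound 3 by 3-fluorophenyl in place of 4-(trifluoromethyl)phenyl on a carbonyl carbon. Replacing the trifluoromethyl-bearing ring with a ring carrying one fluorine resembles the reverse of those two steps, so a somewhat lower number is expected for compound 4 in this assay, though the difference may fall within the scatter. The value expected for compound 4 is 9000 nM, with a likely range from 4500 nM to 18000 nM, an expected step of a 1.9-fold lower number from compound 3 to compound 4 (0.29 log units; within the scatter).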

Compound 4, half-maximal inhibitory concentration: 8780 nM
The estimate for compound 4 lay 1.0-fold (0.01 log units) above the measured number; the range from low to high includes it.
By their numbers in this assay, from the lowest: compounds 1, 4, 2 and 3 (each within the scatter of the next, the first and the last beyond it).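

The 3-fluorophenyl group gives a 2.0-fold lower number from compound 3 to compound 4 (0.30 log units; within the scatter) as well as a 1.2-fold lower number from compound 2 to compound 4 (0.09 log units; within the scatter) and a 1.4-fold higher number from compound 1 to compound 4 (0.15 log units; within the scatter) and so all three steps stay within the scatter. Compound 4 therefore cannot be told apart from any of the other three, even though compound 1 and compound 3 can be told apart from each other. Nothing measured here gives a reason for these small differences. Still open, on these data alone, is whether a ring carrying an amine or a carboxylic acid, or a longer chain in place of the ring, would move the number on this carbonyl carbon beyond the scatter.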